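Swapping benzoxazole for benzothiazole on a weak quinolone

The source may report more compounds than this note shows. Statements on the series, on what has been measured and on what is new or still open speak of the compounds shown alone.

Compound 1 `CCn1cc(-c2nc3ccccc3o2)c(=O)c2cc(F)c(N3CCNC(C)C3)c(F)c21` gives 83500 nM in a functional assay on A2780 cells (Homo sapiens) for cytotoxicity, read by MTT assay, with a stated time of 48 h; a higher number here means a weaker inhibitor, a lower number a stronger inhibitor. Compound 2 `CCn1cc(-c2nc3ccccc3o2)c(=O)c2cc(F)c(N3CCN(C)CC3)cc21` is built on a different core; how the two cores differ is not broken down here. In this assay compound 2 gives 700 nM, and compound 3 `CCn1cc(-c2nc3ccccc3s2)c(=O)c2cc(F)c(N3CCN(C)CC3)cc21` gives 114000 nM. The change 1,3-benzothiazol-2-yl in place of 1,3-benzoxazol-2-yl on an aromatic carbon made a step of a 160-fold higher number from compound 2 to compound 3 (2.21 log units; beyond the scatter). Compound 4 `CCn1cc(-c2nc3ccccc3s2)c(=O)c2cc(F)c(N3CCNC(C)C3)c(F)c21` carries the same change on the core of compound 1, (1,3-benzothiazol-2-yl in place of 1,3-benzoxazol-2-yl on an aromatic carbon), described in identical words for its place. Because compound 1 already gives 83500 nM, a step as large as a 160-fold higher number from compound 2 to compound 3 (2.21 log units; beyond the scatter) would carry compound 4 past what this assay usually resolves, so a smaller and uncertain shift of a 3.0-fold higher number from compound 1 to compound 4 (0.48 log units; beyond the scatter) is expected. Compound 4 is therefore estimated at 250000 nM, within a range from 60000 nM to 1500000 nM.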

Compound 4, half-maximal inhibitory concentration: 9800 nM
Compound 4: middle estimate off by 26-fold (1.41 log units), on the high side, outside the stated range (below it).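

In this assay, putting 1,3-benzothiazol-2-yl in place of 1,3-benzoxazol-2-yl on the core of compound 1 gave an 8.5-fold lower number from compound 1 to compound 4 (0.93 log units; beyond the scatter). That runs opposite to the earlier step, and the two results clearly disagree: the same change on two cores in this assay, a 160-fold higher number (2.21 log units; beyond the scatter) from compound 2 to compound 3 and an 8.5-fold lower number (0.93 log units; beyond the scatter) from compound 1 to compound 4, 1400-fold (3.14 log units) apart, beyond the scatter of two such steps

In this series, then, neither the size nor the direction of this change carries over from one core to the other. Two pairs cannot show which difference between the cores decides the outcome, nor how a third core would respond.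

The compounds shown leave open how a benzimidazol-2-yl group, or a carboxylic acid in the same place, would behave on either core.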